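This account rests on a few compounds, and the source may have more. Where it says the series, first, only, none or still open, it means among the compounds named here.

Working notes on the series.

Compound 3 `Fc1cnc(Nc2cc3[nH]c(-c4cccc(C(F)(F)F)c4)nc3cn2)c(F)c1` is the anchor for this step. In a physicochemical assay for solubility, using the shake flask method, measured as kinetic solubility, with a stated time of 20 h, at pH 2 (on this read-out higher numbers stand for higher solubility and lower numbers for lower solubility), compound 3 gives only < 5000 nM, which is a limit of the assay and not a number, at the limit of < 5000 nM in this assay, at which 1 of the 3 values shown sits. For context, compound 1 `COc1cccc(Nc2cc3[nH]c(-c4cccc(C(F)(F)F)c4)nc3cn2)n1` gives 85000 nM in this assay, and compound 2 `FC(F)(F)c1cccc(-c2nc3cnc(Nc4ncccn4)cc3[nH]2)c1` gives 155000 nM. The step of a 1.8-fold higher number from compound 1 to compound 2 (0.26 log units; within the scatter) shows the two aryl groups on the anilinic nitrogen sit within the scatter of each other, whereas an at least 17-fold lower number from compound 1 to compound 3 (1.23 log units; beyond the scatter) and an at least 31-fold lower number from compound 2 to compound 3 (1.49 log units; beyond the scatter) show that the 3,5-difluoropyridin-2-yl group carries the series to the floor of the assay.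

Compound 4 `O=C(O)c1ccc(Nc2cc3[nH]c(-c4cccc(C(F)(F)F)c4)nc3cn2)nc1` follows from compound 3 by 5-carboxypyridin-2-yl in place of 3,5-difluoropyridin-2-yl on a nitrogen on an aromatic ring. Among the compounds with values here, no measured step covers a carboxy group on this position, so the two large drops into compound 3 are the only guide, and they bear on the group that leaves, not on the one that enters. Compound 4 is estimated at 10000 nM, with a range of 2500 nM to 40000 nM, which would be a step of an at least 2.0-fold higher number from compound 3 to compound 4 (0.30 log units; that floor lies within the scatter) from the limit, and a fair chance remains that this assay again reports only a limit for compound 4.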

Compound 4, solubility: < 5000 nM
Compound 4: a limit, no number; the forecaster's own chance of this, stated with the estimate: 35%; middle value at least 2.0-fold (0.30 log units) away from the limit.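

In this assay compound 4 gives < 5000 nM as a limit and not a number: the limit of < 5000 nM in this assay, at which 2 of the 4 values shown sit. With 5-carboxypyridin-2-yl on the nitrogen the series shows an at least 31-fold lower number from compound 2 to compound 4 (1.49 log units; beyond the scatter) and an at least 17-fold lower number from compound 1 to compound 4 (1.23 log units; beyond the scatter) and so the large drop at this place is no longer tied to 3,5-difluoropyridin-2-yl alone. The step between compound 3 and compound 4 cannot be read, since both values are limits, and the two groups cannot be put in order on this read-out.

Going by these compounds, how far compound 3 and compound 4 lie under their limits stays open. Also open, on these data alone, is whether a pyridin-2-yl group carrying an amine or a methyl ester in place of the carboxylic acid returns to the level of compound 1 and compound 2.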